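A few compounds are considered here, and "the series" means these few. Any claim that something is new, unique, unknown or untested is made for them only; others in the source may bear on it.

The set comprises three measured compounds sharing one core. Compound 1 `CCC1(Cc2ccccc2)OS(=O)(=O)C=C1OC(c1ccccc1)c1ccccc1` was tested in an ADME assay on HEL cells (Homo sapiens) for cytotoxicity, with a stated time of 3 days; on this read-out lower numbers stand for higher toxicity in this test and higher numbers for lower toxicity in this test. In this assay compound 1 gives >= 80000 nM, a limit of the assay rather than a number. Compound 3 `CCCC1(Cc2ccccc2)OS(=O)(=O)C=C1OCc1ccccc1` in this assay gives >= 400000 nM, again a limit. Compound 2 `CCC1(Cc2ccccc2)OS(=O)(=O)C=C1OCc1ccc(Cl)c(Cl)c1` in this assay gives >= 20000 nM, which is also a limit, so for compound 2 only a boundary and no measured figure stands. Among the measured compounds shown here, all three values are limits of this kind, as the limit of >= 20000 nM in this assay, at which 1 of the 3 values shown sits, the limit of >= 80000 nM in this assay, at which 1 of the 3 values shown sits, and the limit of >= 400000 nM in this assay, at which 1 of the 3 values shown sits, show, so no compound can be ranked against another. The unmeasured compound 4 `CCC1(Cc2ccccc2)OS(=O)(=O)C=C1OCc1ccc(C)cc1` differs from compound 2 in one place: 4-methylphenyl in place of 3,4-dichlorophenyl on a saturated chain carbon bound to an oxygen on an unsaturated carbon. For the measured compounds named here, no step between measured compounds is available to set a size for this change. Every measured value reaches only a limit, and no shift beyond the scatter is anticipated. The expected step is a step that the limit leaves unreadable from compound 2 to compound 4. Compound 4 is therefore estimated at 100000 nM, within a range from 20000 nM to 400000 nM, most likely reported again as a limit.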

Compound 4, minimum cytotoxic concentration: >= 16000 nM
Compound 4: only a limit was reported (the forecaster's own chance of this, stated with the estimate: 80%); the middle value does not contradict the limit.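

Among the compounds shown here, compound 2 and compound 4 both stand only as limits in this assay, so no step between them can be read. The compounds shown leave open whether 4-methylphenyl in place of 3,4-dichlorophenyl changes the minimum cytotoxic concentration at all, and how any of these compounds ranks against another.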